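Octylsulfanyl in place of propylamino on a cytotoxicity-limited core

This account rests on a few compounds, and the source may have more. Where it says the series, first, only, none or still open, it means among the compounds named here.

Measured compounds:
- compound 1, `CCCNc1nc(N)nc2c1ncn2/C=C1/CC1(CO)CO`: > 20000 nM (a limit of the assay)
- compound 2, `CCCCNc1nc(N)nc2c1ncn2/C=C1/CC1(CO)CO`: > 20000 nM (a limit of the assay)

In an ADME assay on BCBL1 cells (Homo sapiens) for cytotoxicity, with a stated time of 7 days (a lower number here means that less compound is tolerated, a higher number that more compound is tolerated), compound 1 gives > 20000 nM, which is a limit of the assay rather than a number. Compound 2 likewise gives > 20000 nM, again a limit. Among the compounds with values here, the one measured step, a step that the two limits leave unreadable from compound 1 to compound 2, therefore cannot be read, since both ends sit where the limit of > 20000 nM in this assay, at which 2 of the 2 values shown sit, applies; it says nothing about how far tolerance might extend.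

Compound 3, `CCCCCCCCSc1nc(N)nc2c1ncn2/C=C1/CC1(CO)CO`, differs from compound 1 by octylsulfanyl in place of propylamino on an aromatic carbon. Within the data shown here, no measured step bears on this change, and the octylsulfanyl group is not represented among the measured compounds. With both values known only as limits, the step expected in this assay cannot be anchored; compound 3 is expected to give roughly 15000 nM, within 3000 nM to 40000 nM, corresponding to an expected step of an at least 1.3-fold lower number from compound 1 to compound 3 (0.12 log units; that floor lies within the scatter), and a further limit is the more likely outcome.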

Compound 3, half-maximal cytotoxic concentration: > 20000 nM
Compound 3 gave a limit, no number; the forecaster's own chance of this, stated with the estimate: 60%; middle value at least 1.3-fold (0.12 log units) from the limit.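

In this assay compound 3 gives > 20000 nM, a limit of the assay, so the steps to it from compound 1 and compound 2 cannot be read: the limit of > 20000 nM in this assay, at which 3 of the 3 values shown sit. The compounds shown leave open whether octylsulfanyl and propylamino differ at all in tolerance, and at what concentration any of the three becomes cytotoxic.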